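The source may hold more compounds than are shown below. What is called first, only, known or untested is meant among the compounds shown, and "the series" means these compounds.

Of the compounds shown here, two have so far been measured in a functional assay on MCF7 cells (Homo sapiens) for antiproliferative activity, read by CCK-8 assay, with a stated time of 72 h; a lower number here means a stronger inhibitor of growth, a higher number a weaker inhibitor of growth. Compound 1 `CCC1C(=O)N(C)c2cnc(-n3ccc4cc(C(=O)NCC(C)C)ccc43)nc2N1c1ccn(C)n1` gives 4810 nM in this assay. Compound 2 `CCCCNC(=O)c1ccc2c(ccn2-c2ncc3c(n2)N(c2ccn(C)n2)C(CC)C(=O)N3C)c1`, which carries a butyl group on the amide-type nitrogen, gives 8990 nM in this assay; its number sits at the top of the two measured, but the gap to compound 1 is inside the scatter, since a 1.9-fold higher number from compound 1 to compound 2 (0.27 log units; within the scatter). Compound 3 `CCC1C(=O)N(C)c2cnc(-n3ccc4cc(C(=O)NC5CCCC5)ccc43)nc2N1c1ccn(C)n1` has not yet been measured. It differs from compound 2 in one place: cyclopentyl in place of butyl on an amide-type nitrogen. Among the measured compounds shown here, the only measured step touches the same amide-type nitrogen, swapping one small saturated chain for another, and it moved the number little. With no larger effect on record, the coming step in this assay is expected to stay within the scatter, with no clear direction. Compound 3 is therefore estimated at 7000 nM, with an expected range from 2500 nM to 20000 nM. The expected step is a 1.3-fold lower number from compound 2 to compound 3 (0.11 log units; within the scatter).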

Compound 3, concentration for 50% growth inhibition: "not active" (no number reported)
Nothing numeric was reported for compound 3; there is nothing to compare the estimate with.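

Among the compounds shown here, compound 3 is reported as not active in this assay, without a number, so no step from compound 2 to compound 3 can be read. How far cyclopentyl in place of butyl shifts growth inhibition stays open, and no available data explain the result.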